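This account rests on a few compounds, and the source may have more. Where it says the series, first, only, none or still open, it means among the compounds named here.

Working notes on the series. Compound 1 `COc1cc(-c2nc3cc(/C=C4\SC(=O)NC4=O)ccc3[nH]2)cc(OC)c1OC` gives 6830 nM in a functional assay on MDA-MB-231 cells (Homo sapiens) for inhibition, read by MTT assay, with a stated time of 48 h; a higher number here means a weaker inhibitor, a lower number a stronger inhibitor; compound 2 `COc1ccc(-c2nc3cc(/C=C4\SC(=O)NC4=O)ccc3[nH]2)cc1OC` gives 13600 nM; compound 3 `COc1cc(-c2nc3cc(/C=C4\SC(=O)N(CC(=O)N5CCOCC5)C4=O)ccc3[nH]2)cc(OC)c1OC` gives 14900 nM, the highest of the three numbers. Two measured steps exist: a 2.0-fold higher number from compound 1 to compound 2 (0.30 log units; within the scatter) and a 2.2-fold higher number from compound 1 to compound 3 (0.34 log units; beyond the scatter). Compound 4 `COc1cc(OC)c(-c2nc3cc(/C=C4\SC(=O)N(CC(=O)N5CCOCC5)C4=O)ccc3[nH]2)cc1OC` differs from compound 3 by 2,4,5-trimethoxyphenyl in place of 3,4,5-trimethoxyphenyl on an aromatic carbon. Within the data shown here, neither measured step rearranges the methoxy groups on that ring, so there is no direct precedent; both steps were small, and a step of no more than that size is expected here, with no clear direction. Compound 4 is therefore expected near 18000 nM, within 6000 nM to 50000 nM. The expected step of a 1.2-fold higher number from compound 3 to compound 4 (0.08 log units; within the scatter) is estimated to stay within the scatter.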

Compound 4, half-maximal inhibitory concentration: 21300 nM
For compound 4 the middle estimate is 1.2-fold (0.07 log units) below the measured one; the measured number falls inside the stated range.
By their numbers in this assay, from the lowest: compounds 1, 2, 3 and 4 (each within the scatter of the next, the first and the last beyond it).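

In this assay, this position tolerates a rearrangement of the methoxy groups: 2,4,5-trimethoxyphenyl in place of 3,4,5-trimethoxyphenyl gives a 1.4-fold higher number from compound 3 to compound 4 (0.16 log units; within the scatter). The earlier steps shown here changed the number of methoxy groups or the substituent on the amide-type nitrogen, whereas this one keeps the atoms of the group the same and changes only how they are joined. Nothing available bears on the cause of this result.

Going by these compounds, whether the same rearrangement behaves alike with hydrogen on that nitrogen remains open. So does the outcome with a different kind of group at this position, such as a pyridine ring or a carboxylic acid on the phenyl ring.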